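Lengthening the Amide Chain on Two Related Cores

The source may report more compounds than this note shows. Statements on the series, on what has been measured and on what is new or still open speak of the compounds shown alone.

Compound 1, `CNC(=O)/C=C1/COc2cc(OS(=O)(=O)c3cccc(Cl)c3)ccc21`: 0%
Compound 2, `CCNC(=O)/C=C1/COc2cc(OS(=O)(=O)c3cccc(Cl)c3)ccc21`: 0%
Compound 3, `CNC(=O)Cc1coc2cc(OS(=O)(=O)c3cccc(Cl)c3)ccc12`: 4%

Of the compounds shown here, three have been tested in an assay (strain Sprague-Dawley) for inhibition of Amine oxidase [flavin-containing] B (Rattus norvegicus), read by spectrophotometry, with a stated time of 5 min, tested at 10 uM; on this read-out lower numbers stand for less inhibition and higher numbers for more inhibition at the one concentration tested (going by the name of the read-out). Compound 1 gives 0%, compound 2 gives 0% and compound 3 gives 4%; all three lie within the usual scatter of one another, so none can be set apart. Compound 2 differs from compound 1 by methyl in place of hydrogen on a saturated chain carbon bound to an amide-type nitrogen, and the step of no change at the digits printed from compound 1 to compound 2 (within the scatter). The difference between the core of compound 1 and the core of compound 3 is not broken down here. Compound 4, `CCNC(=O)Cc1coc2cc(OS(=O)(=O)c3cccc(Cl)c3)ccc12`, has not yet been measured; it differs from compound 3 by methyl in place of hydrogen on a saturated chain carbon bound to an amide-type nitrogen, the same change. Little movement is expected in this assay, because no change at the digits printed from compound 1 to compound 2 (within the scatter). The expected step is estimated as no change at the digits printed from compound 3 to compound 4 (within the scatter). Compound 4 is therefore expected to give about 4% in this assay, most likely between 0% and 14%.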

Compound 4, a percentage reported as inhibition, at one concentration (the size of the read-out at that concentration, not a potency): 0%
Compound 4: the middle estimate sits 4 percentage points above what was measured; low and high end bracket the measured number.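

In this assay, replacing hydrogen with methyl, which turns methylcarbamoyl into ethylcarbamoyl, gives a number 4 percentage points lower from compound 3 to compound 4 (within the scatter). Set beside the earlier step, the same change behaves alike on the two cores: the same change on two cores in this assay, no change at the digits printed (within the scatter) from compound 1 to compound 2 and a number 4 percentage points lower (within the scatter) from compound 3 to compound 4, 4 percentage points apart, within the scatter of two such steps. This shows no sign that the core alters the result of this change, but it does not show that the change would carry over to a core with clear inhibition, as all four compounds read low and close together.

Going by these compounds, whether a longer chain such as propyl on the amide nitrogen would read differently in this assay remains open. So does the effect of a carboxylic acid or an amine in place of the amide.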